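Swapping the side group on the pyridine ring of compound 3

The source may report more compounds than this note shows. Statements on the series, on what has been measured and on what is new or still open speak of the compounds shown alone.

Of the compounds shown here, three sharing one core have been measured in an assay on membranes from brain for displacement of a labelled ligand from Neuronal acetylcholine receptor; alpha4/beta2 (Rattus norvegicus); on this read-out lower numbers stand for stronger inhibition and higher numbers for weaker inhibition. Compound 1, `CN1CCC[C@H]1COc1cncc(Br)c1`, gives 0.27 nM. Compound 2, `CCCc1cncc(OC[C@@H]2CCCN2C)c1`, gives 0.12 nM. Compound 3, `CC(C)Cc1cncc(OC[C@@H]2CCCN2C)c1`, gives 0.21 nM. Among these three numbers compound 3 stands second highest; it differs from compound 1 by a 1.3-fold lower number from compound 1 to compound 3 (0.11 log units; within the scatter) and from compound 2 by a 1.8-fold higher number from compound 2 to compound 3 (0.24 log units; within the scatter), so all three sit close together.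

Compound 4, `COC(=O)c1cncc(OC[C@@H]2CCCN2C)c1`, is the next member. The change from compound 3 is methoxycarbonyl in place of isobutyl on an aromatic carbon. Going by the values given here, no measured step involves a methoxycarbonyl group, so the closest guidance comes from the other exchanges at the same aromatic carbon: a 2.3-fold lower number from compound 1 to compound 2 (0.35 log units; beyond the scatter) and a 1.3-fold lower number from compound 1 to compound 3 (0.11 log units; within the scatter). Both are small, which suggests that this position tolerates different groups without large shifts in this assay. Given this, compound 4 is expected to move by only a 1.9-fold higher number from compound 3 to compound 4 (0.28 log units; within the scatter), a step that may well stay within the scatter. The estimate for compound 4 in this assay is therefore 0.4 nM, with a plausible range from 0.15 nM to 1.5 nM.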

Compound 4, inhibition constant: 1.45 nM
Compound 4: middle estimate off by 3.6-fold (0.56 log units), on the low side; measured number inside the range.
By their numbers in this assay, from the lowest: compounds 2, 3 and 1 (each within the scatter of the next, the first and the last beyond it); then compound 4.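

The aromatic carbon two atoms from the ring nitrogen proves less forgiving in this assay than the bromo, propyl and isobutyl compounds suggested: methoxycarbonyl brings a 6.9-fold higher number from compound 3 to compound 4 (0.84 log units; beyond the scatter), a 12-fold higher number from compound 2 to compound 4 (1.08 log units; beyond the scatter) and a 5.4-fold higher number from compound 1 to compound 4 (0.73 log units; beyond the scatter), each larger than any step among the first three compounds. Isobutyl and methoxycarbonyl both have 4 heavy atoms, so heavy-atom count alone does not set the number here; what differs is that the entering group has oxygen atoms, a double bond and hydrogen-bond acceptors. No measurement shown gives a reason for the rise.

The compounds shown leave open whether the rise follows the carbonyl or the other oxygen: an acetyl group or a methoxymethyl chain on this carbon would separate the two. On these data alone, how an amide or a carboxylic acid would read here is also open.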